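Swapping one amine ring for a bicyclic amine

A few compounds are considered here, and "the series" means these few. Any claim that something is new, unique, unknown or untested is made for them only; others in the source may bear on it.

Of the compounds shown here, three built on a shared core have been measured in an ADME assay on HOS cells (Homo sapiens) for cytotoxicity; on this read-out higher numbers stand for lower toxicity in this test and lower numbers for higher toxicity in this test. Compound 1 `CN1CCN(c2cccn3cc(CN(C)[C@H]4CCCc5cccnc54)nc23)CC1` gives > 5000 nM in this assay, which is a limit of the test rather than a number. Compound 2 `CN(C)[C@@H]1CCN(c2cccc3nc(CN(C)[C@H]4CCCc5cccnc54)cn23)C1` gives 4900 nM in this assay. Compound 3 `CN1CCN(c2cccc3nc(CN(Cc4ccccc4)[C@H]4CCCc5cccnc54)cn23)CC1` gives 9300 nM in this assay. Of the two plain numbers, compound 2 holds the lower one, and its gap to compound 3 lies within the usual scatter, so the two cannot be told apart. Compound 4 `CN(Cc1cn2c(N3CCN4CCCC4C3)cccc2n1)[C@H]1CCCc2cccnc21` has not yet been measured. It differs from compound 2 by a group of 9 heavy atoms (7 carbon, 2 nitrogen; one five-membered non-aromatic ring with 1 hetero atom, one six-membered non-aromatic ring with 2 hetero atoms) in place of a group of 8 heavy atoms (6 carbon, 2 nitrogen; one five-membered non-aromatic ring with 1 hetero atom), on an aromatic carbon. For the measured compounds named here, no measured pair of compounds shows a step of this kind, so there is no measured step to lean on. With all three known results sitting close to one another, the change is expected to shift the number by no more than the scatter, in no particular direction. Compound 4 is therefore expected to give about 5500 nM in this assay, somewhere between 2500 nM and 12000 nM. The expected step of a 1.1-fold higher number from compound 2 to compound 4 (0.05 log units; within the scatter) thus stays within the scatter.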

Compound 4, half-maximal cytotoxic concentration: 3900 nM
Compound 4: middle estimate off by 1.4-fold (0.15 log units), on the high side; the range from low to high includes it.
By their numbers in this assay, from the lowest: compounds 4, 2 and 3 (each within the scatter of the next, the first and the last beyond it).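

At this position, on an aromatic carbon next to the ring nitrogen, the 3-(dimethylamino)pyrrolidin-1-yl group can be replaced by an amine with one five-membered and one six-membered non-aromatic ring, and this assay gives a 1.3-fold lower number from compound 2 to compound 4 (0.10 log units; within the scatter). For the compounds shown here, this is the first measured step between two compounds that differ in only one place, and it shows that adding the second ring leaves the read-out indistinguishable from that of compound 2. Compound 1 still gives a limit of the test rather than a number: the limit of > 5000 nM in this assay, at which 1 of the 4 values shown sits.

One step at one position cannot show how far this tolerance extends. A morpholine or an open-chain amine such as dimethylamino in the same place could stay within the scatter or move beyond it, and the compounds shown leave that open.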